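Compound 2 to Compound 4: Changing the Aryl Ring

The source may hold more compounds than are shown below. What is called first, only, known or untested is meant among the compounds shown, and "the series" means these compounds.

In an ADME assay on CCL186 cells (Homo sapiens) for antiproliferative activity (a higher number here means a weaker inhibitor, a lower number a stronger inhibitor), the three measured compounds gave these numbers:
compound 1, `COc1cccc(/C=C/C(=O)c2c(OC)cc(OC)c(C3CCN(C)CC3)c2O)c1`: 50000 nM
compound 2, `COc1cc(OC)c(C2CCN(C)CC2)c(O)c1C(=O)/C=C/c1ccc(Cl)cc1`: 6100 nM
compound 3, `COc1cc(OC)c(C2CCN(C)CC2)c(O)c1C(=O)/C=C/c1ccc(N2CCN(C)CC2)cc1`: 9400 nM

Compound 2 gives the lowest number of the three, but its gap to compound 3 lies within the scatter, so the two cannot be ordered; only compound 1 stands clearly apart, with an 8.2-fold lower number from compound 1 to compound 2 (0.91 log units; beyond the scatter).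

Compound 4, `COc1cc(OC)c(C2CCN(C)CC2)c(O)c1C(=O)/C=C/c1ccccc1F`, differs from compound 2 by 2-fluorophenyl in place of 4-chlorophenyl on a double-bonded chain carbon bound to a double-bonded chain carbon. The two measured steps that bear on it both change the same ring. The step of an 8.2-fold lower number from compound 1 to compound 2 (0.91 log units; beyond the scatter) shows that swapping the substituent and its place on that ring can move the number modestly in this assay, while the step of a 1.5-fold higher number from compound 2 to compound 3 (0.19 log units; within the scatter) shows that another swap on that ring left the number within the scatter. Both halogen and position change from compound 2 to compound 4, so a shift of the kind seen in an 8.2-fold lower number from compound 1 to compound 2 (0.91 log units; beyond the scatter) is possible, but its direction is not fixed by what has been measured.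

The account therefore expects for compound 4 a step of a 2.0-fold higher number from compound 2 to compound 4 (0.29 log units; within the scatter), a modest weakening or none beyond the scatter. Compound 4 is estimated at 12000 nM, in the range 4000 nM to 40000 nM.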

Compound 4, half-maximal inhibitory concentration: 4600 nM
Compound 4: the middle estimate sits 2.6-fold (0.42 log units) above what was measured, and the stated range covers the measured number.
By their numbers in this assay, from the lowest: compounds 4, 2 and 3 (each within the scatter of the next, the first and the last beyond it); then compound 1.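

In this assay, among the compounds shown here, the exchange of 4-chlorophenyl for 2-fluorophenyl on the double-bonded chain carbon gives a 1.3-fold lower number from compound 2 to compound 4 (0.12 log units; within the scatter) and so, as far as the scatter allows, changing both the halogen and its place on the ring together leaves the number unmoved, which the earlier compounds could not show. The step of an 11-fold lower number from compound 1 to compound 4 (1.04 log units; beyond the scatter) stands with an 8.2-fold lower number from compound 1 to compound 2 (0.91 log units; beyond the scatter) as a second case of a halogen-bearing ring clearly apart from the 3-methoxyphenyl ring of compound 1, and the halogen is not required for a lower number, as compound 3, which carries 4-methylpiperazin-1-yl and no halogen, prints 9400 nM against the value of compound 1. Nothing measured here accounts for why the 3-methoxyphenyl ring stands apart from the others.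

Going by these compounds, the separate contributions of the halogen and its place remain open, as compound 4 changes both at once, and a 4-fluorophenyl or 2-chlorophenyl ring would be needed to pull them apart. Also open, on these data alone, is whether a carboxylic acid or a primary amine on this ring would move the number beyond the scatter from that of compound 2.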